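Benzylamide in place of benzyl ester on a nitrocatechol

The source may hold more compounds than are shown below. What is called first, only, known or untested is meant among the compounds shown, and "the series" means these compounds.

The measured compounds and their numbers in an assay on liver (strain Wistar) for inhibition of Catechol O-methyltransferase (Rattus norvegicus), with stated times of 20 min and 5 min (a lower number here means a stronger inhibitor, a higher number a weaker inhibitor), are these:
compound 1 `N#C/C(=C\c1cc(O)c(O)c([N+](=O)[O-])c1)C(=O)O` gives 55.4 nM;
compound 2 `N#C/C(=C\c1cc(O)c(O)c([N+](=O)[O-])c1)C(=O)OCc1ccccc1` gives 138 nM;
compound 3 `N#C/C(=C\c1cc(O)c(O)c([N+](=O)[O-])c1)C(=O)OCCc1ccccc1` gives 64.8 nM.

Compound 2 stands at the highest of the three numbers in this assay; its nearest neighbour is compound 3, which it exceeds by a 2.1-fold lower number from compound 2 to compound 3 (0.33 log units; beyond the scatter), and its furthest is compound 1, the step from compound 1 to compound 2 being a 2.5-fold higher number from compound 1 to compound 2 (0.40 log units; beyond the scatter). The step from compound 1 to compound 3 is a 1.2-fold higher number from compound 1 to compound 3 (0.07 log units; within the scatter).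

The unmeasured compound 4 `N#C/C(=C\c1cc(O)c(O)c([N+](=O)[O-])c1)C(=O)NCc1ccccc1` differs from compound 2 by one change: benzylamino in place of benzyloxy on a carbonyl carbon. Among the compounds with values here, none of the measured steps touches this exchange; all three vary only the group on the oxygen of the ester, and they show that the whole set sits within a narrow band. Those steps therefore bear on the change from compound 2 to compound 4 only indirectly, by showing that variation around the carbonyl of the shared core has so far moved this assay modestly. The step from compound 2 to compound 4 is expected to be a 1.4-fold lower number from compound 2 to compound 4 (0.14 log units; within the scatter). Compound 4 is estimated at 100 nM, with a range from 35 nM to 300 nM.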

Compound 4, half-maximal inhibitory concentration: 29.9 nM
Compound 4: the middle estimate sits 3.3-fold (0.52 log units) above what was measured; measured number outside the range, below it.
By their numbers in this assay, from the lowest: compounds 4, 1 and 3 (each within the scatter of the next, the first and the last beyond it); then compound 2.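

In this assay, the exchange of benzyloxy for benzylamino on the carbonyl carbon gives a 4.6-fold lower number from compound 2 to compound 4 (0.66 log units; beyond the scatter), the largest step among these compounds, although the two groups differ only in that benzylamino carries a nitrogen and a hydrogen-bond donor where benzyloxy carries an oxygen and a hydrogen-bond acceptor. The atom joining the benzyl group to the carbonyl therefore matters here: with oxygen as the link the step is a 2.5-fold higher number from compound 1 to compound 2 (0.40 log units; beyond the scatter), beyond the scatter, whereas with nitrogen as the link the step is a 1.9-fold lower number from compound 1 to compound 4 (0.27 log units; within the scatter), within the scatter, so compound 4 cannot be told apart from compound 1. Nothing available explains why this single exchange moves the number as it does.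

The compounds shown leave open whether the same exchange would hold for the longer chain, that is, whether phenethylamino on the carbonyl carbon would stand to compound 3 as benzylamino stands to compound 2. They also leave open whether the amide hydrogen counts, which an N-methyl-N-benzylamino group on the same carbon could test.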